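This account rests on a few compounds, and the source may have more. Where it says the series, first, only, none or still open, it means among the compounds named here.

Measured compounds:
compound 1 `COC(=O)NC1=CS(=O)(=O)O[C@@]12[C@@H](CO[Si](C)(C)C(C)(C)C)O[C@@H](n1cc(C)c(=O)n(C)c1=O)[C@@H]2O[Si](C)(C)C(C)(C)C` gives > 200000 nM
compound 2 `Cc1cn([C@@H]2O[C@H](CO[Si](C)(C)C(C)(C)C)[C@@]3(OS(=O)(=O)C=C3NCC(=O)C(=O)O)[C@H]2O[Si](C)(C)C(C)(C)C)c(=O)n(C)c1=O` gives 146000 nM
compound 3 `Cc1cn([C@@H]2O[C@H](CO[Si](C)(C)C(C)(C)C)[C@@]3(OS(=O)(=O)C=C3NCC(=O)C(N)=O)[C@H]2O[Si](C)(C)C(C)(C)C)c(=O)n(C)c1=O` gives 14500 nM

In a functional assay on HEL cells (Homo sapiens) (on this read-out lower numbers stand for higher toxicity in this test and higher numbers for lower toxicity in this test), compound 1 does not give a number but only a limit, (the limit of > 200000 nM in this assay, at which 1 of the 3 values shown sits). Compound 1 therefore stands at the untoxic end of the three measured values, though how far beyond that limit it lies is not known. Compound 4 `COC(=O)CCNC1=CS(=O)(=O)O[C@@]12[C@@H](CO[Si](C)(C)C(C)(C)C)O[C@@H](n1cc(C)c(=O)n(C)c1=O)[C@@H]2O[Si](C)(C)C(C)(C)C` is not yet measured. It differs from compound 1 at a single place: 2-(methoxycarbonyl)ethyl in place of methoxycarbonyl on an amine nitrogen. The ester stays, and only a longer chain now links it to the amine nitrogen.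

Two measured steps start from the same place on compound 1. The step of an at least 1.3-fold lower number from compound 1 to compound 2 (0.13 log units; that floor lies within the scatter) is small. The step of an at least 13-fold lower number from compound 1 to compound 3 (1.13 log units; beyond the scatter) is large, and the difference between compound 2 and compound 3 comes down to a 10-fold lower number from compound 2 to compound 3 (1.00 log units; beyond the scatter), so the amide is what drives the gain in toxicity. Neither step inserts a chain while keeping the ester, so they guide only loosely. Since the ester of compound 1 is kept, little change in this assay is expected, with a step of a number no higher from compound 1 to compound 4 (the limit leaves the size open). Compound 4 is expected to give 200000 nM, between 60000 nM and 400000 nM, with a fair chance that only a limit is again reported.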

Compound 4, half-maximal cytotoxic concentration: 94000 nM
Compound 4: middle estimate off by 2.1-fold (0.33 log units), on the high side; the range from low to high includes it.
By their numbers in this assay, from the lowest: compound 3; then compounds 4 and 2 (each within the scatter of the next). At a limit, above all of these: compound 1.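

In this assay, the amine nitrogen responds even when the ester is kept: swapping methoxycarbonyl for 2-(methoxycarbonyl)ethyl gives an at least 2.1-fold lower number from compound 1 to compound 4 (0.32 log units; beyond the scatter), so the toxicity reading does not depend on the amide alone. Compound 1 gives only a limit, which makes the size of this step a floor: the limit of > 200000 nM in this assay, at which 1 of the 4 values shown sits. The amide-bearing chain still stands apart, with a 6.5-fold higher number from compound 3 to compound 4 (0.81 log units; beyond the scatter), whereas the ester and acid chains cannot be told apart, with a 1.6-fold lower number from compound 2 to compound 4 (0.19 log units; within the scatter).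

As far as these compounds go, how a longer chain ending in the same ester, or a chain ending in a primary amine, would read in this assay stays open. Whether the ester matters at all, or the chain alone is enough, would take a plain propyl group on the amine nitrogen to show.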